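Para substituent on the aroyl ring: hydroxy to nitro

The compounds below may be only part of what the source reports. "The series", "measured", "known", "first", "only" and "open" are said of these compounds alone.

Measured in a functional assay on PC-3 cells (Homo sapiens) for cytotoxicity, read by MTT assay, with a stated time of 48 h; on this read-out higher numbers stand for weaker inhibition and lower numbers for stronger inhibition:
compound 1 `COc1cc(-c2nnc3n2NC(c2ccco2)C(C(=O)c2ccc(C)cc2)S3)cc(OC)c1OC` gives 7500 nM
compound 2 `COc1cc(-c2nnc3n2NC(c2ccco2)C(C(=O)c2ccc(O)cc2)S3)cc(OC)c1OC` gives 38300 nM

Going by the values given here, compound 2 stands at the highest of the two numbers so far; the single measured step, a 5.1-fold higher number from compound 1 to compound 2 (0.71 log units; beyond the scatter), separates it from the only other compound. Compound 3 `COc1cc(-c2nnc3n2NC(c2ccco2)C(C(=O)c2ccc([N+](=O)[O-])cc2)S3)cc(OC)c1OC` differs from compound 2 by nitro in place of hydroxy on an aromatic carbon. Among the compounds with values here, the one step that bears on this position, a 5.1-fold higher number from compound 1 to compound 2 (0.71 log units; beyond the scatter), shows that swapping the group at this carbon moves the read-out by a modest amount, beyond the scatter. Within the data shown here, no measured compound carries a nitro group, so its direction is open; the two substituents seen so far bracket a modest range and a nitro group is expected to land somewhere within or near it. Compound 3 is therefore expected to give about 15000 nM, with a range from 4000 nM to 60000 nM, which would mean a step of a 2.6-fold lower number from compound 2 to compound 3 (0.41 log units; beyond the scatter) relative to compound 2.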

Compound 3, half-maximal inhibitory concentration: 27900 nM
The estimate for compound 3 lay 1.9-fold (0.27 log units) below the measured number; low and high end bracket the measured number.
By their numbers in this assay, from the lowest: compound 1; then compounds 3 and 2 (each within the scatter of the next).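

In this assay, going from hydroxy to nitro gives a 1.4-fold lower number from compound 2 to compound 3 (0.14 log units; within the scatter) and so does not separate the two groups, although they differ in heavy atoms and hydrogen-bond donors. Nitro in place of methyl gives a 3.7-fold higher number from compound 1 to compound 3 (0.57 log units; beyond the scatter) and confirms with a second group what the hydroxy step alone suggested: compound 1, with methyl, stands apart from both other compounds beyond the scatter, with the lowest number of the three. Nothing measured on these compounds accounts for this grouping.

Open, going by these compounds, is whether an amine, a carboxylic acid, a methoxy group or a chlorine at this carbon would fall with methyl or with hydroxy and nitro. Also open, on these data alone, is whether the gap between methyl and the other two groups holds when the rest of the shared core is changed.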